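The source may report more compounds than this note shows. Statements on the series, on what has been measured and on what is new or still open speak of the compounds shown alone.

Measured in a functional assay on SGC-7901 cells (Homo sapiens) for antiproliferative activity, read by MTT assay, with a stated time of 72 h; on this read-out higher numbers stand for weaker inhibition and lower numbers for stronger inhibition:

Compound 1 `CCOC(=O)c1cc(-c2ccc(OC)c(OCc3ccccc3)c2)c(-c2cc(OC)c(OC)c(OC)c2)s1`: > 100000 nM (a limit of the assay, not a number)
Compound 2 `COc1ccc(-c2ccsc2-c2cc(OC)c(OC)c(OC)c2)cc1`: 2740 nM
Compound 3 `COc1ccc(-c2ccsc2-c2cc(OC)c(OC)c(OC)c2)cc1[N+](=O)[O-]`: 10300 nM

Of the two true numbers in this assay, the higher belongs to compound 3, which sits a 3.8-fold higher number from compound 2 to compound 3 (0.58 log units; beyond the scatter) on swapping a hydrogen for nitro. The next compound, compound 4 `COc1ccc(-c2ccsc2-c2cc(OC)c(OC)c(OC)c2)cc1OCc1ccccc1`, replaces that nitro with benzyloxy on the same aromatic carbon (benzyloxy in place of nitro on an aromatic carbon). For the measured compounds named here, no measured step isolates benzyloxy, so the evidence is indirect. Going by the values given here, the single clean step, a 3.8-fold higher number from compound 2 to compound 3 (0.58 log units; beyond the scatter), shows that this carbon tolerates substitution poorly, at a modest size. Compound 1 also carries benzyloxy, and it reports only the limit > 100000 nM, though it differs elsewhere as well. On this basis a further modest move towards weaker inhibition is expected, with the estimated change being a 2.4-fold higher number from compound 3 to compound 4 (0.39 log units; beyond the scatter). For compound 4 the estimated value is 25000 nM, with an expected range from 5000 nM to 100000 nM.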

Compound 4, half-maximal inhibitory concentration: > 100000 nM
Compound 4: a limit, no number; the forecaster's own chance of this, stated with the estimate: 25%; at least 4.0-fold (0.60 log units) between middle value and limit.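

Benzyloxy on this aromatic carbon, ortho to a methoxy group, costs far more than the modest loss seen with nitro: in this assay the change from hydrogen gives an at least 36-fold higher number from compound 2 to compound 4 (1.56 log units; beyond the scatter), and the change from nitro gives an at least 9.7-fold higher number from compound 3 to compound 4 (0.98 log units; beyond the scatter). Compound 4 lacks the ethoxycarbonyl group of compound 1 yet also stands at a limit of the assay, so in this pair benzyloxy reaches that limit without the ethoxycarbonyl group. Both readable steps are open-ended, and the step between compound 1 and compound 4 cannot be read: the limit of > 100000 nM in this assay, at which 2 of the 4 values shown sit.

The compounds shown leave open whether a hydroxy group or an amine on this carbon would match or improve on compound 2. They also leave open how far the true value of compound 4 lies beyond the limit.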